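This account rests on a few compounds, and the source may have more. Where it says the series, first, only, none or still open, it means among the compounds named here.

Compound 1 `CC(=O)Nc1ccc(S(=O)(=O)NNC(=O)c2cccnc2Nc2ccc(Cl)cc2)cc1` was tested in a functional assay on KM12 cells (Homo sapiens) for antiproliferative activity; a higher number here means that more compound is tolerated, a lower number that less compound is tolerated. In this assay compound 1 gave only a limit, > 100000 nM, and no number. Compound 2 `O=C(NNS(=O)(=O)c1ccc(F)cc1)c1cccnc1Nc1ccc(Cl)cc1Cl`, a related compound with a different substitution pattern, was also examined in this assay. For compound 2 the result was likewise a limit, > 100000 nM. Both values therefore sit at the same point, (the limit of > 100000 nM in this assay, at which 2 of the 2 values shown sit), so compound 1 stands at the edge of what the assay can report rather than at a measured concentration. Compound 3 `O=C(NNS(=O)(=O)c1ccc(Cl)cc1Cl)c1cccnc1Nc1ccc(Cl)cc1` differs from compound 1 in one place: 2,4-dichlorophenyl in place of 4-acetamidophenyl on a sulfonyl sulfur. Among the compounds with values here, no measured step between compounds is available to guide this change. The expected step in this assay, a number no higher from compound 1 to compound 3 (the limit leaves the size open), is none beyond the scatter, since both measured compounds returned limits. Compound 3 is accordingly expected to give about 100000 nM, within a range from 20000 nM to 500000 nM, most likely again as a limit.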

Compound 3, concentration lethal to 50% of the cells: 58900 nM
Estimate against measurement, compound 3: 1.7-fold (0.23 log units) above; the measured number falls inside the stated range.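

In this assay, compound 3 is the only compound shown that returns a number rather than a limit, so a change of group on the sulfonyl sulfur can bring a reading within what the assay reports. Placing 2,4-dichlorophenyl there in place of 4-acetamidophenyl gives an at least 1.6-fold lower number from compound 1 to compound 3 (0.22 log units; that floor lies within the scatter), so the limit leaves the true size of the step open and its floor alone does not separate the two compounds. The single number stands against a background of limits: the limit of > 100000 nM in this assay, at which 2 of the 3 values shown sit.

The compounds shown do not tell whether the step depends on the chlorine atoms or on the loss of 4-acetamidophenyl. On these data alone, whether 4-chlorophenyl or 4-aminophenyl on the sulfonyl sulfur would also return a number stays open.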